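Allyloxy for benzyloxy at the assay limit

The compounds below may be only part of what the source reports. "The series", "measured", "known", "first", "only" and "open" are said of these compounds alone.

Within the data shown here, in an ADME assay on RAW264.7 cells (Mus musculus) for cytotoxicity, read by neutral red uptake, with a stated time of 24 h (a lower number here means that less compound is tolerated, a higher number that more compound is tolerated), the series so far offers limits only. Compound 1 (`C=CCONC(=O)C(C)N1C(=O)S/C(=C\c2ccccc2)C1=O`) carries an allyloxy group and gives > 128000 nM as a limit of the assay, not a number. Compound 2 (`C=CCONC(=O)CN1C(=O)S/C(=C\c2ccc(C(F)(F)F)cc2)C1=O`) also carries allyloxy and gives > 128000 nM as a limit. Compound 3 (`CC(C(=O)NOCc1ccccc1)N1C(=O)S/C(=C\c2ccc(C(F)(F)F)cc2)C1=O`) carries benzyloxy and gives > 128000 nM as a limit as well, so no number places it relative to the other two. Among the measured compounds shown here, the position of the series is the limit of > 128000 nM in this assay, at which 3 of the 3 values shown sit, and no measured step is available.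

Compound 4 (`C=CCONC(=O)C(C)N1C(=O)S/C(=C\c2ccc(C(F)(F)F)cc2)C1=O`) is unmeasured. Relative to compound 3 it has vinyl in place of phenyl on a saturated chain carbon bound to an oxygen, that is, benzyloxy to allyloxy (vinyl in place of phenyl on a saturated chain carbon bound to an oxygen). No clear change is expected in this assay because compound 2 with its allyloxy group gives > 128000 nM as a limit. The estimated a number no higher from compound 3 to compound 4 (the limit leaves the size open) is expected to stay within the scatter. Compound 4 is estimated at 128000 nM within an expected range from 64000 nM to 256000 nM and will most likely be reported as a limit again.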

Compound 4, half-maximal cytotoxic concentration: > 128000 nM
Compound 4: only a limit was reported; the forecaster's own chance of this, stated with the estimate: 85%; the middle value lies on the limit itself.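

In this assay compound 4 gives > 128000 nM, a limit of the assay. Its steps from compound 1, compound 2 and compound 3 therefore cannot be read. The compounds shown leave open where the half-maximal cytotoxic concentration of any of them lies, and whether allyloxy and benzyloxy differ at all: the limit of > 128000 nM in this assay, at which 4 of the 4 values shown sit.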